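The source may hold more compounds than are shown below. What is called first, only, known or untested is meant among the compounds shown, and "the series" means these compounds.

Measured so far, in a functional assay on CNE-2 cells (Homo sapiens) for antiproliferative activity, read by sulforhodamine B assay, with a stated time of 48 h; a higher number here means a weaker inhibitor, a lower number a stronger inhibitor:

compound 1, `COc1ccc(OC)c(/C=C/C(=O)C(=Cc2ccc(O)c(OC)c2)C(=O)/C=C/c2cc(OC)ccc2OC)c1`: 340 nM
compound 2, `COc1ccc(OC)c(/C=C/C(=O)C(=Cc2ccc(O)c(F)c2)C(=O)/C=C/c2cc(OC)ccc2OC)c1`: 380 nM
compound 3, `COc1ccc(/C=C/C(=O)C(=Cc2ccc(O)c(OC)c2)C(=O)/C=C/c2ccc(OC)cc2OC)c(OC)c1`: 970 nM

Compound 1 and compound 2 share a core and differ by fluoro in place of methoxy on an aromatic carbon. This change gives a 1.1-fold higher number from compound 1 to compound 2 (0.05 log units; within the scatter). Compound 3 has the same atoms as compound 1 joined differently; the difference between the two cores is not broken down here. Compound 3 gives the highest number of the three in this assay, beyond the scatter from both compound 1 and compound 2.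

Compound 4, `COc1ccc(/C=C/C(=O)C(=Cc2ccc(O)c(F)c2)C(=O)/C=C/c2ccc(OC)cc2OC)c(OC)c1`, is not yet measured. It differs from compound 3 by fluoro in place of methoxy on an aromatic carbon, the same change as from compound 1 to compound 2, at the same place. Because a 1.1-fold higher number from compound 1 to compound 2 (0.05 log units; within the scatter) lies within the scatter, the step from compound 3 to compound 4 is expected to be small as well, estimated at a 1.1-fold higher number from compound 3 to compound 4 (0.03 log units; within the scatter). Compound 4 is therefore expected to give about 1050 nM in this assay, with a likely range from 550 nM to 2000 nM.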

Compound 4, half-maximal inhibitory concentration: 2830 nM
Estimate against measurement, compound 4: 2.7-fold (0.43 log units) below; measured number outside the range, above it.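

In this assay, fluoro in place of methoxy on the core of compound 3 gives a 2.9-fold higher number from compound 3 to compound 4 (0.47 log units; beyond the scatter), whereas the same change on the core of compound 1 stays within the scatter. Set side by side, the two steps cannot be told apart, so the data do not show that the core alters the effect of this change: the same change on two cores in this assay, a 1.1-fold higher number (0.05 log units; within the scatter) from compound 1 to compound 2 and a 2.9-fold higher number (0.47 log units; beyond the scatter) from compound 3 to compound 4, 2.6-fold (0.42 log units) apart, within the scatter of two such steps. Nor do two pairs establish that the change carries over unaltered, or fix a size to expect on a further core.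

Still open, going by these compounds, is whether other groups at this place, such as chloro, an amine or ethoxy, behave alike on both cores. Also open, on these data alone, is how this step reads on a third core.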